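The source may hold more compounds than are shown below. What is called first, only, known or untested is meant among the compounds shown, and "the series" means these compounds.

Working notes on the series. For the measured compounds named here, compound 2 `Cc1oc(-c2c(Cl)cccc2Br)nc1CN1CCC(C(=O)NCCCN2C[C@H](C)C[C@H](C)C2)CC1` is tested in an ADME assay on Huh7.5.1 cells (Homo sapiens) for cytotoxicity, read by ATP content, with a stated time of 48 h (on this read-out lower numbers stand for higher toxicity in this test and higher numbers for lower toxicity in this test), where compound 2 gives 12200 nM, the higher of the two numbers so far; its nearest neighbour is compound 1 `Cc1oc(-c2ccc(Cl)cc2)nc1CN1CCC(C(=O)NCCCN2C[C@H](C)C[C@H](C)C2)CC1`, which in this assay gives 11500 nM. Going by the values given here, the one measured step, a 1.1-fold higher number from compound 1 to compound 2 (0.03 log units; within the scatter), changes the aryl group and stays within the scatter. Compound 3 `COc1cccc(Br)c1-c1nc(CN2CCC(C(=O)NCCCN3C[C@H](C)C[C@H](C)C3)CC2)c(C)o1` is not yet measured; it differs from compound 2 by methoxy in place of chloro on an aromatic carbon. Among the compounds with values here, no measured step exchanges these two groups, so the only guide is that the aryl change from compound 1 to compound 2 left the read-out in this assay unchanged within the scatter. Another change on the same aryl ring is therefore expected to give no step beyond the scatter, a 1.0-fold lower number from compound 2 to compound 3 (0.01 log units; within the scatter). For compound 3 in this assay the estimate is 12000 nM, with a range from 6000 nM to 24000 nM.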

Compound 3, half-maximal cytotoxic concentration: 14900 nM
For compound 3 the middle estimate is 1.2-fold (0.09 log units) below the measured one; the measured number falls inside the stated range.
By their numbers in this assay, from the lowest: compounds 1, 2 and 3 (each within the scatter of the next).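

In this assay, methoxy in place of chloro on an aromatic carbon ortho to a large group gives a 1.2-fold higher number from compound 2 to compound 3 (0.09 log units; within the scatter) with the bromo group kept, so this single exchange, which brings in one hydrogen-bond acceptor, stays within the scatter. Set against the 4-chlorophenyl group of compound 1, the 2-bromo-6-methoxyphenyl group gives a 1.3-fold higher number from compound 1 to compound 3 (0.11 log units; within the scatter) and also stays within the scatter, which places all three aryl groups shown within the scatter of each other on this read-out. No measurement at hand bears on the reason for these numbers.

From the compounds shown here alone, whether an amine or a carboxylic acid on this aryl ring would give a step beyond the scatter remains open. Going by these compounds, all three compounds share everything outside the aryl group, so the effect of a longer chain elsewhere on the shared core also remains open.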